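A few compounds are considered here, and "the series" means these few. Any claim that something is new, unique, unknown or untested is made for them only; others in the source may bear on it.

Measured in a functional assay on COR-L23 cells (Homo sapiens) for antiproliferative activity, read by CellTiter-Glo, with a stated time of 4 days; a lower number here means a stronger inhibitor, a higher number a weaker inhibitor:

- Compound 1 `COCC(=O)N[C@@H](C)c1ccc(NC(=O)[C@H]2C[C@@H]2c2cccnc2)cc1`: 111 nM
- Compound 2 `C[C@H](NC(=O)c1ccccc1)c1ccc(NC(=O)[C@H]2C[C@@H]2c2cccnc2)cc1`: 8 nM

Of these two numbers, compound 2 holds the lower, and the gap to compound 1 lies beyond the scatter. Compound 3 `C[C@H](NC(=O)c1ncccn1)c1ccc(NC(=O)[C@H]2C[C@@H]2c2cccnc2)cc1` has not yet been measured in this assay. It differs from compound 2 in one place: pyrimidin-2-yl in place of phenyl on a carbonyl carbon. In short, pyrimidin-2-yl stands in place of phenyl on a carbonyl carbon.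

Among the measured compounds shown here, only one measured step bears on this place. It is a 14-fold lower number from compound 1 to compound 2 (1.14 log units; beyond the scatter), a large step that put phenyl in place of methoxymethyl. It shows that a change on this carbonyl carbon can move the number a long way, but it does not compare two aromatic rings. For the measured compounds named here, no measured compound carries pyrimidin-2-yl, so the direction remains a judgement. Compound 3 keeps a six-membered aromatic ring here, so a much smaller shift than a 14-fold lower number from compound 1 to compound 2 (1.14 log units; beyond the scatter) is expected, towards a higher number. The expected change is a 3.1-fold higher number from compound 2 to compound 3 (0.49 log units; beyond the scatter). For compound 3 the estimated value is 25 nM, with an expected range of 6 nM to 100 nM.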

Compound 3, half-maximal inhibitory concentration: 17 nM
Compound 3: the middle estimate sits 1.5-fold (0.17 log units) above what was measured; low and high end bracket the measured number.
By their numbers in this assay, from the lowest: compound 2; then compound 3; then compound 1.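

Until now, this assay offered only a comparison of methoxymethyl with phenyl on this carbonyl carbon, and that did not show how far the number depends on the make-up of the aromatic ring. Exchanging the carbon-only ring for pyrimidin-2-yl, which brings 2 nitrogen atoms and 2 hydrogen-bond acceptors into a ring of the same size, gives a 2.1-fold higher number from compound 2 to compound 3 (0.33 log units; beyond the scatter), a modest step but one beyond the scatter, so this position does distinguish between these two six-membered aromatic rings. Compound 3 nevertheless keeps much of the gain over the methoxymethyl amide, with a 6.5-fold lower number from compound 1 to compound 3 (0.81 log units; beyond the scatter), so among these three compounds both aromatic groups give lower numbers than methoxymethyl, and nothing available explains the difference between phenyl and pyrimidin-2-yl.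

The compounds shown leave open whether the higher number of compound 3 follows the number of ring nitrogens or their placement, a question that pyridin-2-yl or pyrimidin-5-yl on the same carbonyl carbon would address. They also leave open whether an aromatic ring is needed here at all, since no saturated ring such as cyclohexyl appears among them.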